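Shortening the carboxy-bearing chain of an isoflavone ether

This account rests on a few compounds, and the source may have more. Where it says the series, first, only, none or still open, it means among the compounds named here.

Measured compounds:
compound 1 `O=C(O)CCCCCCCCCCCCCCCOc1ccc2c(=O)c(-c3ccc(O)cc3)coc2c1`, > 9000 nM in an assay (Cricetulus griseus) for inhibition of aldehyde dehydrogenase, mitochondrial (Homo sapiens); on this read-out lower numbers stand for stronger inhibition and higher numbers for weaker inhibition
compound 2 `O=C(O)CCCCOc1ccc2c(=O)c(-c3ccc(O)cc3)coc2c1`, 100 nM
compound 3 `CCCCCCCCCCCCOc1ccc2c(=O)c(-c3ccc(O)cc3)coc2c1`, > 9000 nM

The value of compound 1 is a limit of this assay, not a number. The value of compound 3 is likewise a limit, as the limit of > 9000 nM in this assay, at which 2 of the 3 values shown sit, records. Among the measured compounds shown here, compound 2 thus stands alone as the only true number among the three.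

Compound 4 `O=C(O)COc1ccc2c(=O)c(-c3ccc(O)cc3)coc2c1` differs from compound 2 by carboxy in place of 3-carboxypropyl on a saturated chain carbon bound to an oxygen on an aromatic ring. Of the measured steps, an at least 90-fold higher number from compound 2 to compound 3 (1.95 log units; beyond the scatter) is the nearest relative, changing the same chain; a step that the two limits leave unreadable from compound 1 to compound 3 is not readable. Compound 4 keeps the carboxy group, so a step of modest size, if any, is expected: a 2.5-fold higher number from compound 2 to compound 4 (0.40 log units; beyond the scatter). Compound 4 is estimated at 250 nM, between 60 nM and 1500 nM.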

Compound 4, half-maximal inhibitory concentration: 1200 nM
Compound 4: the middle estimate sits 4.8-fold (0.68 log units) below what was measured, within the range that was stated.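

Compound 4 keeps the carboxy group and still gives a 12-fold higher number from compound 2 to compound 4 (1.08 log units; beyond the scatter) in this assay, so keeping that group is not enough to hold the inhibition seen with compound 2. The earlier step to compound 3 removed the carboxy group as it changed the chain, whereas this one changes only the length of the carboxy-bearing chain, and that change alone moves the number strongly. Compound 1, on the long side, sits at > 9000 nM, which is a limit of this assay and not a number.

Nothing shown gives a cause for this loss. Open, on these data alone, is how chains of intermediate length would behave, and whether an amine or an amide at the chain end could stand in for the carboxylic acid.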